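This account rests on a few compounds, and the source may have more. Where it says the series, first, only, none or still open, it means among the compounds named here.

Compound 1 `COc1ccc2c(C3(c4c[nH]c5cc(OC)ccc45)C(=O)Nc4ccccc43)c[nH]c2c1` carries two methoxy-bearing indole units on a shared core. In a functional assay on HepG2 cells (Homo sapiens) for cytotoxicity, read by MTT assay, with a stated time of 48 h (a lower number here means a stronger inhibitor, a higher number a weaker inhibitor), compound 1 gives 12000 nM. Compound 3 `COc1ccc2c(C3(c4c[nH]c5cc(OC)ccc45)C(=O)Nc4ccc(F)cc43)c[nH]c2c1` differs from it by fluoro in place of hydrogen on an aromatic carbon. In this assay compound 3 gives 16000 nM, so the step of a 1.3-fold higher number from compound 1 to compound 3 (0.12 log units; within the scatter) is one that the scatter of the measurement can account for on its own.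

Compound 2 `O=C1Nc2ccccc2C1(c1c[nH]c2ccc(Br)cc12)c1c[nH]c2ccc(Br)cc12` replaces both methoxy groups of compound 1 with bromine; how the two cores differ is not broken down here. In this assay compound 2 gives 15800 nM. Its number and those of compound 1 and compound 3 all lie within the usual scatter of one another, so no order among the three can be read from them.

Compound 4 `O=C1Nc2ccc(F)cc2C1(c1c[nH]c2ccc(Br)cc12)c1c[nH]c2ccc(Br)cc12` has not yet been measured. It differs from compound 2 by fluoro in place of hydrogen on an aromatic carbon. The place of the entering fluorine is described in the same words as for the change from compound 1 to compound 3, so this is the same change on the brominated core. Among the measured compounds shown here, since the only measured instance of it, a 1.3-fold higher number from compound 1 to compound 3 (0.12 log units; within the scatter), stayed within the scatter, the step from compound 2 to compound 4 is expected to be similar in size, estimated at a 1.2-fold higher number from compound 2 to compound 4 (0.08 log units; within the scatter). On that basis compound 4 is expected to give about 19000 nM in this assay, most likely between 9000 nM and 40000 nM, with some chance that the assay reports only a limit.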

Compound 4, half-maximal inhibitory concentration: 12800 nM
The estimate for compound 4 lay 1.5-fold (0.17 log units) above the measured number; measured number inside the range.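

On the brominated core, fluoro in place of hydrogen on an aromatic carbon gives a 1.2-fold lower number from compound 2 to compound 4 (0.09 log units; within the scatter) in this assay, a step that the scatter can account for on its own. Set beside the earlier step, this one gives no sign that the change behaves differently on the two cores: the same change on two cores in this assay, a 1.3-fold higher number (0.12 log units; within the scatter) from compound 1 to compound 3 and a 1.2-fold lower number (0.09 log units; within the scatter) from compound 2 to compound 4, 1.6-fold (0.22 log units) apart, within the scatter of two such steps. In these two pairs, then, the change left the number within the scatter on both cores, but no direction can be read from either step, and two pairs do not show that the change is without effect or that it would carry over in the same way to other cores in this series.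

The compounds shown leave open whether any other group at the place taken by the fluorine, such as a chloro, a nitrile, a methyl or an amine, would move the number beyond the scatter. They also leave open what a carboxylic acid or a longer chain in place of the methoxy or bromine on the indole units would do, and whether a substituent on the amide nitrogen in place of the amide hydrogen would change the number in this assay.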